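The compounds below may be only part of what the source reports. "The series", "measured", "known", "first", "only" and "open" are said of these compounds alone.

Measured so far in an assay on membranes from brain for binding affinity to adenosine receptor A1 (Rattus norvegicus), read by radioligand binding, tested at 20 uM; on this read-out higher numbers stand for more inhibition at the one concentration tested (going by the name of the read-out) and lower numbers for less inhibition:
compound 1 `Cn1c(=O)[nH]c2c(cnn2-c2ccccc2[N+](=O)[O-])c1=N`: 5%
compound 2 `Cn1c(=O)[nH]c2c(cnn2-c2cccc([N+](=O)[O-])c2)c1=N`: 2%
compound 3 `Cn1c(=O)[nH]c2c(cnn2-c2ccccc2F)c1=N`: 8%

All three numbers lie within the scatter of one another, so compound 3 does not stand apart from compound 1 or compound 2 in this assay; the series as a whole shows little inhibition at the single concentration. Among the compounds with values here, the one single-place step, a number 3 percentage points higher from compound 1 to compound 3 (within the scatter), is within the scatter.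

Compound 4 `Cn1c(=O)[nH]c2c(cnn2-c2ccccc2N)c1=N` differs from compound 3 in one place: amino in place of fluoro on an aromatic carbon. Within the data shown here, no measured step exchanges fluoro for amino, so the only guide is the flat run of the three measured compounds and the small size of a number 3 percentage points higher from compound 1 to compound 3 (within the scatter). The step from compound 3 to compound 4 is therefore expected to be none beyond the scatter, a number 2 percentage points lower from compound 3 to compound 4 (within the scatter). For compound 4 in this assay the estimate is 6%, with a range from 0% to 16%.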

Compound 4, a percentage reported as inhibition, at one concentration (the size of the read-out at that concentration, not a potency): 0%
For compound 4 the middle estimate is 6 percentage points above the measured one, within the range that was stated.
By their numbers in this assay, from the lowest: compounds 4, 2, 1 and 3 (each within the scatter of the next).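

In this assay the exchange for amino gives a number 8 percentage points lower from compound 3 to compound 4 (within the scatter) and a number 5 percentage points lower from compound 1 to compound 4 (within the scatter) as well. Fluoro, nitro and amino at this place therefore read alike, even though amino brings a hydrogen-bond donor that fluoro lacks. No data at hand offer a reason for this flat result.

Open, from the compounds shown here alone, is whether any group on this aromatic carbon moves the read-out beyond the scatter, for example a carboxylic acid or a longer chain such as butoxy. Also open, going by these compounds, is whether the unsubstituted phenyl ring would read any differently from these compounds.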